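From cyclobutyl to benzylamino on the carbonyl carbon

The source may hold more compounds than are shown below. What is called first, only, known or untested is meant among the compounds shown, and "the series" means these compounds.

Among the compounds with values here, in a functional assay on A2780 cells (Homo sapiens) for antiproliferative activity, read by fluorescence, with a stated time of 72 h (a lower number here means a stronger inhibitor, a higher number a weaker inhibitor), compound 3 `CN1CCC(C(=O)N2Cc3c(NC(=O)C4CCC4)n[nH]c3C2(C)C)CC1` gives the lowest of the three numbers so far (140 nM), and its gaps to the other two lie beyond the scatter. Compound 2 `CC(C)(C)C(=O)N1Cc2c(NC(=O)C3CCNCC3)n[nH]c2C1(C)C` reads higher (650 nM), and compound 1 `CN1CCC(C(=O)N2Cc3c(NC(=O)C4CC4)n[nH]c3C2(C)C)CC1` also reads higher (1420 nM).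

The next compound, compound 4 `CN1CCC(C(=O)N2Cc3c(NC(=O)NCc4ccccc4)n[nH]c3C2(C)C)CC1`, keeps the rest of compound 3 and carries benzylamino in place of cyclobutyl on a carbonyl carbon. Within the data shown here, only one measured step touches this place: cyclobutyl in place of cyclopropyl on a carbonyl carbon, which gave a 10-fold lower number from compound 1 to compound 3 (1.01 log units; beyond the scatter) and counts as large. A small change there therefore moved the number well beyond the scatter, so a much larger change may also move it. Among the measured compounds shown here, no measured compound carries benzylamino, so the direction remains uncertain. Compound 3 already holds the lowest number (140 nM), so a rise is the more likely outcome. The expected change is a 2.9-fold higher number from compound 3 to compound 4 (0.46 log units; beyond the scatter) and would probably be smaller than the measured step. For compound 4 the estimated value is 400 nM with an expected range of 80 nM to 2000 nM in this assay as a wide allowance for this untested group.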

Compound 4, half-maximal inhibitory concentration: 2680 nM
Beside the measured number, compound 4's estimate is 6.7-fold (0.83 log units) below it, and the stated range ends below it.
By their numbers in this assay, from the lowest: compound 3; then compound 2; then compounds 1 and 4 (each within the scatter of the next).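

In this assay, within the data shown here, the earlier compounds showed only that this position responds to a small change between two carbon rings, whereas the step to benzylamino gives a 19-fold higher number from compound 3 to compound 4 (1.28 log units; beyond the scatter), so the low number of compound 3 does not survive a switch to this larger aromatic group. Set against the smaller ring, the same group gives a 1.9-fold higher number from compound 1 to compound 4 (0.28 log units; within the scatter), which places compound 1 and compound 4 within the scatter of each other and shows that the step from cyclopropyl to cyclobutyl does not extend into a rising trend with group size across these three compounds. No measurement of any other kind bears on why the number changes at this position.

The change from cyclobutylcarbonyl to benzylcarbamoyl alters the ring and adds the nitrogen with its hydrogen-bond donor in one step, so the compounds shown cannot separate these contributions. A cyclobutylamino group or a benzyl group on the same carbonyl carbon would change one of them alone, and a cyclopentyl group would show whether a carbon ring larger than cyclobutyl keeps the lower number.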